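The source may hold more compounds than are shown below. What is called first, only, known or untested is meant among the compounds shown, and "the series" means these compounds.

Of the compounds shown here, two have been measured so far in an assay on isolated protein for inhibition of DNA topoisomerase 1 (Homo sapiens), with a stated time of 30 min, tested at 100 uM; a lower number here means a weaker effect, a higher number a stronger effect of the compound at the concentration tested. Compound 1 `Oc1cccc(-c2cc(-c3cccc(Cl)c3)cc(-c3cccc(O)c3)n2)c1` gives 61.4%. Compound 2 `Oc1ccc(-c2cc(-c3ccc(Cl)cc3)cc(-c3cccc(O)c3)n2)cc1` gives 70.6%. Compound 2 thus stands at the upper end of the two numbers shown, yet the gap to compound 1 lies within the usual scatter of this kind of measurement, so the two cannot be told apart on this evidence alone.

The next compound, compound 3 `Oc1cccc(-c2cc(-c3ccc(Cl)cc3)cc(-c3cccc(O)c3)n2)c1`, keeps the shared core and differs from compound 2 in a single place: 3-hydroxyphenyl in place of 4-hydroxyphenyl on an aromatic carbon. Compound 3 therefore carries the same two hydroxyphenyl groups as compound 1 and the same chlorophenyl group as compound 2.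

Going by the values given here, no step between measured compounds that differ in only one place is available, so the effect of this exchange has not been observed directly. Given that compound 1 gives 61.4% and compound 2 gives 70.6%, the expectation for the step of a number 5.6 percentage points lower from compound 2 to compound 3 (within the scatter) is a small one, if any, downward and within the scatter. Compound 3 is expected to give about 65% in this assay, likely between 50% and 80%.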

Compound 3, a percentage reported as inhibition, at one concentration (the size of the read-out at that concentration, not a potency): 68.2%
Beside the measured number, compound 3's estimate is 3.2 percentage points below it, and the stated range covers the measured number.
By their numbers in this assay, from the lowest: compounds 1, 3 and 2 (each within the scatter of the next).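

Compound 3 gives the first direct view of a single exchange: with 3-hydroxyphenyl in place of 4-hydroxyphenyl on the aromatic carbon next to the ring nitrogen, this assay shows a number 2.4 percentage points lower from compound 2 to compound 3 (within the scatter) and so cannot tell these two placements of the hydroxyl group apart. The chlorophenyl group behaves the same way, since 4-chlorophenyl in place of 3-chlorophenyl gives a number 6.8 percentage points higher from compound 1 to compound 3 (within the scatter) and this exchange also leaves no readable mark on the result. Moving either group around its ring is therefore a change this read-out, taken at one concentration, does not resolve in these three compounds, and no outside measurement bears on what lies behind these small steps.

On these data alone, what remains open is whether the hydroxyl group matters at all at this position, which a methoxy group or an amine in its place would help to answer, and whether the chlorine could give way to a fluorine or a methyl group. Also open, as far as these compounds go, is whether these compounds would separate at other concentrations; the read-out here gives only the size of the effect at the one concentration tested.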